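A few compounds are considered here, and "the series" means these few. Any claim that something is new, unique, unknown or untested is made for them only; others in the source may bear on it.

Series notes. Three ureas on one shared core have been measured in a functional assay on HepG2 cells (Homo sapiens) for inhibition, read by MTT assay, with a stated time of 72 h; on this read-out higher numbers stand for weaker inhibition and lower numbers for stronger inhibition. Compound 1 `O=C(Nc1cccc(OCc2cn(-c3ccccc3)nn2)c1)Nc1ccc(Cl)c(C(F)(F)F)c1` gives 1780 nM. Compound 2 `Cc1ccccc1-n1cc(COc2cccc(NC(=O)Nc3ccc(Cl)c(C(F)(F)F)c3)c2)nn1` gives 3440 nM, and compound 3 `CC(C)c1cccc(-n2cc(COc3cccc(NC(=O)Nc4ccc(Cl)c(C(F)(F)F)c4)c3)nn2)c1` gives 3250 nM. The three numbers sit together: the steps of a 1.9-fold higher number from compound 1 to compound 2 (0.29 log units; within the scatter), a 1.8-fold higher number from compound 1 to compound 3 (0.26 log units; within the scatter) and a 1.1-fold lower number from compound 2 to compound 3 (0.02 log units; within the scatter) are each within the scatter, so compound 3 is not set apart from either of the others. Compound 4 `O=C(Nc1cccc(OCc2cn(-c3cccc(C(F)(F)F)c3)nn2)c1)Nc1ccc(Cl)c(C(F)(F)F)c1` carries the change (trifluoromethyl in place of isopropyl on an aromatic carbon). The measured steps all vary the same position and bear on this change, and each stayed within the scatter, so no step beyond the scatter is expected in this assay in either direction. The expected step is a 1.1-fold lower number from compound 3 to compound 4 (0.03 log units; within the scatter). Compound 4 is therefore estimated at 3000 nM, with a range from 1200 nM to 7500 nM.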

Compound 4, half-maximal inhibitory concentration: 1270 nM
Estimate against measurement, compound 4: 2.4-fold (0.37 log units) above; low and high end bracket the measured number.
By their numbers in this assay, from the lowest: compounds 4, 1, 3 and 2 (each within the scatter of the next, the first and the last beyond it).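

In this assay this position now shows steps beyond the scatter: a 2.6-fold lower number from compound 3 to compound 4 (0.41 log units; beyond the scatter) comes with trifluoromethyl replacing isopropyl, and a 2.7-fold lower number from compound 2 to compound 4 (0.43 log units; beyond the scatter) comes with 3-(trifluoromethyl)phenyl replacing 2-methylphenyl. Hydrogen and trifluoromethyl are not set apart, with a 1.4-fold lower number from compound 1 to compound 4 (0.15 log units; within the scatter) as the step, so the change separates compound 4 from compound 3 and compound 2 only. No supporting data bear on why trifluoromethyl and isopropyl differ here. Still open, on these data alone, is how an amine, a carboxylic acid or a nitrile on this aromatic carbon would compare with compound 4.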